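Taking One Chloro Off Compound 1

This account rests on a few compounds, and the source may have more. Where it says the series, first, only, none or still open, it means among the compounds named here.

Two small amides have been tested so far in a functional assay on K562 cells (Homo sapiens) for cytotoxicity, with a stated time of 72 h; a lower number here means a stronger inhibitor, a higher number a weaker inhibitor. Compound 1 (`CC(C)[C@H](NC(=O)c1cc(Cl)ccc1O)C(=O)Nc1ccc(Cl)cc1`) gives > 20000 nM, which is a limit and not a number. Compound 2 (`C[C@H](NC(=O)c1ccc(Cl)cc1O)C(=O)Nc1ccc(Cl)c(Cl)c1`) gives > 12500 nM, also a limit. Going by the values given here, neither compound has a measured half-maximal value, so compound 1 cannot be ranked against compound 2, and both readings show only that no number was obtained in this assay.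

Compound 3 (`CC(C)[C@H](NC(=O)c1cc(Cl)ccc1O)C(=O)Nc1ccccc1`) keeps the core of compound 1 but has hydrogen in place of chloro on an aromatic carbon, so 4-chlorophenyl becomes phenyl (hydrogen in place of chloro on an aromatic carbon). Among the compounds with values here, no measured pair here shows what this change does, so any forecast is cautious. The forecast rests on compound 1, whose only reading is the limit > 20000 nM. The expected result is no shift beyond the scatter in either direction, and another limit would be no surprise. The estimated step is a step that the limit leaves unreadable from compound 1 to compound 3. For compound 3 the expected value is 25000 nM, with an estimated range from 10000 nM to 80000 nM.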

Compound 3, half-maximal inhibitory concentration: > 10000 nM
Compound 3 was reported as a limit (the forecaster's own chance of this, stated with the estimate: 80%); the middle value does not contradict the limit.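

Compound 1 and compound 3 both read as limits in this assay, not as numbers, so the step between them cannot be read. The compounds shown leave open whether swapping the chloro for hydrogen changes cytotoxicity at all, and at what concentration, if any, either compound would reach its half-maximal effect.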